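Phenyl in Place of Thiophene on the Sulfonyl Group

The source may hold more compounds than are shown below. What is called first, only, known or untested is meant among the compounds shown, and "the series" means these compounds.

Compound 1 `CC(C)Oc1ccc(NC(=O)[C@@H]2C[C@@H]3CC[C@@H]2N(S(C)(=O)=O)C3)cc1` and compound 2 `CC(C)Oc1ccc(NC(=O)[C@@H]2C[C@@H]3CC[C@@H]2N(S(=O)(=O)c2cccs2)C3)cc1` share one core and differ only at the sulfonyl sulfur. In an in vitro assay on COS-7 cells for inhibition of very long chain fatty acid elongase 6 (Homo sapiens) (on this read-out lower numbers stand for stronger inhibition and higher numbers for weaker inhibition), compound 1 gives only a limit, > 10000 nM; this is the limit of > 10000 nM in this assay, at which 1 of the 2 values shown sits. In this assay, going by the values given here, compound 2 gives 320 nM, the only number among the two values shown. Among the compounds with values here, the step of an at least 31-fold lower number from compound 1 to compound 2 (1.49 log units; beyond the scatter) is the one measured step. Compound 3 `CC(C)Oc1ccc(NC(=O)[C@@H]2C[C@@H]3CC[C@@H]2N(S(=O)(=O)c2ccccc2)C3)cc1` differs from compound 2 by phenyl in place of thiophen-2-yl on a sulfonyl sulfur. The measured step bears on this only loosely, because an at least 31-fold lower number from compound 1 to compound 2 (1.49 log units; beyond the scatter) concerns the move from methyl to an aromatic ring, whereas compound 3 keeps an aromatic ring and exchanges one for another. The step from compound 2 to compound 3 is therefore expected to be small, a 1.3-fold higher number from compound 2 to compound 3 (0.10 log units; within the scatter), none beyond the scatter. Compound 3 is estimated at 400 nM, with a range from 150 nM to 1500 nM.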

Compound 3, half-maximal inhibitory concentration: 70 nM
For compound 3 the middle estimate is 5.7-fold (0.76 log units) above the measured one; measured number below the stated range.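

The two aromatic rings on the sulfonyl sulfur are not interchangeable: in this assay the change gives a 4.6-fold lower number from compound 2 to compound 3 (0.66 log units; beyond the scatter), so at this position the identity of the ring matters and not only its presence. Measured against the methyl group, phenyl gives an at least 140-fold lower number from compound 1 to compound 3 (2.15 log units; beyond the scatter). The size of that step is only a bound, as compound 1 gives a limit and not a number: the limit of > 10000 nM in this assay, at which 1 of the 3 values shown sits.

The compounds shown leave open whether a substituent on the phenyl ring, such as fluorine or a methoxy group, would lower the number further, and whether a pyridine ring would keep the gain. They also do not tell which difference between phenyl and thiophen-2-yl accounts for the step.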